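A few compounds are considered here, and "the series" means these few. Any claim that something is new, unique, unknown or untested is made for them only; others in the source may bear on it.

In a functional assay on MCF7 cells (Homo sapiens) for cytotoxicity, read by MTT assay, with a stated time of 48 h (a lower number here means a stronger inhibitor, a higher number a weaker inhibitor), the measured compounds are:

Compound 1 `O=C1/C(=C\c2ccccc2)S/C(=N/c2ccccc2)N1Cc1ccncc1`: 26400 nM
Compound 2 `Cc1ccc(/C=C2/S/C(=N/c3ccccc3)N(Cc3ccncc3)C2=O)cc1`: 36900 nM
Compound 3 `COc1ccc(/C=C2/S/C(=N/c3ccccc3)N(Cc3ccncc3)C2=O)cc1`: 31500 nM

Compound 3, at 31500 nM, cannot be separated from the other two compounds. Its two steps, a 1.2-fold higher number from compound 1 to compound 3 (0.08 log units; within the scatter) and a 1.2-fold lower number from compound 2 to compound 3 (0.07 log units; within the scatter), are both small. Compound 4 `O=C1/C(=C\c2ccc(Cl)cc2)S/C(=N/c2ccccc2)N1Cc1ccncc1` has chloro in place of methoxy on an aromatic carbon, turning 4-methoxyphenyl into 4-chlorophenyl.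

The three measured steps all change the group on this aromatic carbon. Besides the two above, they include a 1.4-fold higher number from compound 1 to compound 2 (0.15 log units; within the scatter). None of them moves the number beyond the scatter. For the measured compounds named here, no chloro compound has been measured, so this evidence is indirect, and chloro could still behave differently. Even so, compound 1, compound 2 and compound 3 give no reason to predict a real shift in this assay.

The expected change is a 1.1-fold lower number from compound 3 to compound 4 (0.04 log units; within the scatter), which means no step beyond the scatter is anticipated. Compound 4 is estimated at 29000 nM, with an expected range of 14000 nM to 55000 nM.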

Compound 4, half-maximal inhibitory concentration: 54900 nM
For compound 4 the middle estimate is 1.9-fold (0.28 log units) below the measured one; the range from low to high includes it.
By their numbers in this assay, from the lowest: compounds 1, 3, 2 and 4 (each within the scatter of the next, the first and the last beyond it).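

In this assay, for the compounds shown here, chloro gives the first step at this position that lies beyond the scatter, though a modest one, when it replaces hydrogen (a 2.1-fold higher number from compound 1 to compound 4 (0.32 log units; beyond the scatter)). Against the other two groups the same chloro stays within the scatter, both in place of methoxy (a 1.7-fold higher number from compound 3 to compound 4 (0.24 log units; within the scatter)) and in place of methyl (a 1.5-fold higher number from compound 2 to compound 4 (0.17 log units; within the scatter)). So this aromatic carbon is not entirely indifferent to what it carries, but among these four compounds only the pair of chloro and hydrogen can be told apart.

Nothing measured here accounts for that single step. Going by these compounds, it also remains open whether an amine or a carboxylic acid on this same aromatic carbon would move the number further, or would stay as close to hydrogen as methyl and methoxy do.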